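This account rests on a few compounds, and the source may have more. Where it says the series, first, only, none or still open, it means among the compounds named here.

Measured compounds:
compound 1, `O=C(O)CCCC1=CC[C@@H]2[C@@H](/C=C/[C@@H](O)COc3ccccc3)[C@H](O)C[C@@H]2OC1` — 640 nM
compound 2, `O=C(O)CC[C@@H]1CC[C@@H]2[C@@H](/C=C/[C@@H](O)COc3ccccc3)[C@H](O)C[C@@H]2OC1` — 1000 nM
compound 3, `O=C(O)CC[C@H]1CC[C@@H]2[C@@H](/C=C/[C@@H](O)COc3ccccc3)[C@H](O)C[C@@H]2OC1` — 110 nM

In a functional assay on CHO cells for agonist activity at prostaglandin F2-alpha receptor (Homo sapiens), read by fluorescence and calcium flux (on this read-out lower numbers stand for an effect already at smaller amounts and higher numbers for an effect only at larger amounts of compound), compound 2 gives the highest of the three numbers. Compound 1 lies nearest to it, a difference that stays within the scatter, so no order between compound 1 and compound 2 is claimed. Compound 3 stands furthest away: a 9.1-fold lower number from compound 2 to compound 3 (0.96 log units; beyond the scatter). The two share every atom and bond and differ only in the configuration as drawn (the fact that compounds 2 and 3 differ only in the configuration as drawn), so this step is the only one measured, and it concerns a stereocentre rather than the chain.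

Compound 4, `O=C(O)CCC[C@@H]1CC[C@@H]2[C@@H](/C=C/[C@@H](O)COc3ccccc3)[C@H](O)C[C@@H]2OC1`, is derived from compound 2 by a single change: carboxymethyl in place of carboxy on a saturated chain carbon, two bonds along the chain from a saturated ring carbon. Put another way, the acid-bearing chain is one carbon longer. No measured step in this set alters the chain, so nothing among the shown steps bears directly on the change from compound 2 to compound 4; the stereo step from compound 2 to compound 3 does not speak to it. In this assay compound 4 is therefore expected to give a number close to that of compound 2, with a 1.7-fold lower number from compound 2 to compound 4 (0.22 log units; within the scatter) as the estimated step, and a broad range is appropriate. For compound 4 the estimate in this assay is 600 nM, between 150 nM and 2500 nM.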

Compound 4, half-maximal effective concentration: 280 nM
Compound 4: the middle estimate sits 2.1-fold (0.33 log units) above what was measured; low and high end bracket the measured number.
By their numbers in this assay, from the lowest: compound 3; then compound 4; then compounds 1 and 2 (each within the scatter of the next).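

In this assay, the change from carboxy to carboxymethyl on a saturated chain carbon, two bonds along the chain from a saturated ring carbon, gives a 3.6-fold lower number from compound 2 to compound 4 (0.55 log units; beyond the scatter). Up to this point, the only step between compounds differing in one place was a change of configuration, so this is the first evidence that the length of the acid-bearing chain also moves the number at this position beyond the scatter, with the longer chain giving the lower number and the configuration of the core left as drawn in compound 2. Nothing in the information at hand explains why lengthening the chain has this effect.

The compounds shown leave open whether a still longer chain ending in a carboxylic acid would continue this direction or reverse it, and whether an ester, an amide or a tetrazole could stand in place of the carboxylic acid at the chain's end. They also leave open whether the same lengthening would act in the same direction and to a similar extent on compound 3, which has the other configuration at the saturated ring carbon.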